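The source may report more compounds than this note shows. Statements on the series, on what has been measured and on what is new or still open speak of the compounds shown alone.

Measured so far in a functional assay for inhibition, with Homo sapiens as the target; on this read-out higher numbers stand for weaker inhibition and lower numbers for stronger inhibition:
compound 1 `O=C(O)CCCCCn1nc(-c2ccccc2)c(-c2ccccc2)c1-c1ccccc1` – > 78000 nM
compound 2 `O=C(O)CCCCCCCCn1nc(-c2ccccc2)c(Cc2ccccc2)c1-c1ccccc1` – > 68000 nM

Compound 1 stands at a limit of this assay: its result > 78000 nM is a limit and not a measured number. Compound 2 likewise gives only a limit, > 68000 nM. Both values therefore sit at the top of what this assay can report (the limit of > 78000 nM in this assay, at which 1 of the 2 values shown sits, (the limit of > 68000 nM in this assay, at which 1 of the 2 values shown sits)), and no order between compound 1 and compound 2 can be read from them. Within the data shown here, the two compounds differ in more than one place, so no single step between them is recorded.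

Compound 3 `CNC(=O)CCCCCCCCn1nc(-c2ccccc2)c(-c2ccccc2)c1-c1ccccc1` has not yet been tested. It differs from compound 1 in one place: 3-(methylcarbamoyl)propyl in place of carboxy on a saturated chain carbon, five bonds along the chain from an aromatic nitrogen. Among the measured compounds shown here, no measured step shows how this kind of change acts in this assay, since neither measured compound yields a number. With nothing pointing toward gained inhibition, compound 3 is expected to remain at or near the limit, and the step that the limit leaves unreadable from compound 1 to compound 3 is estimated as none beyond the scatter. Compound 3 is thus expected to give about 80000 nM, with a range from 20000 nM to 300000 nM, most probably reported again as a limit only.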

Compound 3, half-maximal inhibitory concentration: > 68000 nM
Compound 3 ended at the assay's limit (the forecaster's own chance of this, stated with the estimate: 80%); the middle value is on the limit's open side.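

In this assay compound 3 gives only a limit, > 68000 nM, and not a measured number. Compound 1 also gives only a limit, > 78000 nM. The step from compound 1 to compound 3 therefore cannot be read. The compounds shown leave open whether 3-(methylcarbamoyl)propyl in place of carboxy changes inhibition at all.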